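Growing the Sulfonamide Substituent from Hydrogen to Isopropyl

This account rests on a few compounds, and the source may have more. Where it says the series, first, only, none or still open, it means among the compounds named here.

Compound 1 `CC(C(=O)NCc1ccc(C(F)(F)F)nc1NS(=O)(=O)c1ccccc1)c1ccc(NS(C)(=O)=O)c(F)c1` is reported in an assay on CHO cells for antagonist activity at transient receptor potential cation channel subfamily V member 1 (Homo sapiens), read by scintillation counting, with a stated time of 5 min (a higher number here means a weaker inhibitor, a lower number a stronger inhibitor), only as "active" (no number reported), so it has no single number to stand on. A close relative, compound 2 `CC(C(=O)NCc1ccc(C(F)(F)F)nc1N(C)S(=O)(=O)c1ccccc1)c1ccc(NS(C)(=O)=O)c(F)c1`, carries a methyl on the sulfonamide nitrogen and in this assay gives 100 nM. Compound 3 `CC(C(=O)NCc1ccc(C(F)(F)F)nc1N(C(C)C)S(=O)(=O)c1ccccc1)c1ccc(NS(C)(=O)=O)c(F)c1` takes the same nitrogen one size further: isopropyl in place of hydrogen on a sulfonamide nitrogen. For the measured compounds named here, no measured step covers this change, so its size and direction are open; a modest weakening relative to compound 2 seems somewhat more likely than none beyond the scatter. Compound 3 is therefore expected to give about 200 nM in this assay, with a range from 60 nM to 800 nM.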

Compound 3, inhibition constant: 27.6 nM
Estimate against measurement, compound 3: 7.2-fold (0.86 log units) above, and the stated range ends above it.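

On the sulfonamide nitrogen, isopropyl in place of methyl moves this assay the stronger way, with a 3.6-fold lower number from compound 2 to compound 3 (0.56 log units; beyond the scatter). Across these two groups, then, a larger alkyl group on this nitrogen brings no loss of inhibition, and the number improves instead. Nothing at hand explains this gain.

Compound 1 has no single number, so hydrogen cannot yet be ranked against methyl or isopropyl. Going by these compounds, whether a longer chain such as n-butyl, or a cyclopropyl ring, would continue this change remains open.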